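A few compounds are considered here, and "the series" means these few. Any claim that something is new, unique, unknown or untested is made for them only; others in the source may bear on it.

Measured so far in an assay (Rattus norvegicus) for inhibition of Fatty-acid amide hydrolase 1 (Homo sapiens); on this read-out lower numbers stand for stronger inhibition and higher numbers for weaker inhibition:
- compound 1 `Nc1ccccc1-c1cnc(C(=O)CCCCCCc2ccccc2)o1` gives 750 nM
- compound 2 `O=C(CCCCCCc1ccccc1)c1ncc(-c2cccc(O)c2)o1` gives 50 nM
- compound 3 `N#Cc1cccc(-c2cnc(C(=O)CCCCCCc3ccccc3)o2)c1` gives 15 nM

Compound 3 holds the lowest number of the three in this assay; compound 2 stands nearest to it and compound 1 furthest away. The next step leads to compound 4 `O=C(CCCCCCc1ccccc1)c1ncc(-c2ccc([N+](=O)[O-])cc2)o1`: 4-nitrophenyl in place of 3-cyanophenyl on an aromatic carbon. Going by the values given here, two measured steps bear on the aryl substituent: a 50-fold lower number from compound 1 to compound 3 (1.70 log units; beyond the scatter) and a 3.3-fold lower number from compound 2 to compound 3 (0.52 log units; beyond the scatter), with a 15-fold lower number from compound 1 to compound 2 (1.18 log units; beyond the scatter) as the remaining link. Among the compounds with values here, both steps ending at compound 3 ran toward lower numbers, but no measured pair shows how a 4-nitrophenyl fares, so the direction of this change rests on little. The expectation for compound 4 in this assay is therefore only a small shift, a 2.0-fold higher number from compound 3 to compound 4 (0.30 log units; within the scatter), toward a somewhat higher number, within the usual spread. Compound 4 is estimated at 30 nM, within 8 nM to 120 nM.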

Compound 4, inhibition constant: 50 nM
Compound 4: middle estimate off by 1.7-fold (0.22 log units), on the low side; the measured number falls inside the stated range.
By their numbers in this assay, from the lowest: compound 3; then compounds 2 and 4 (each within the scatter of the next); then compound 1.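

Putting 4-nitrophenyl in place of 3-cyanophenyl gives up a modest amount (a 3.3-fold higher number from compound 3 to compound 4 (0.52 log units; beyond the scatter)), so compound 3 keeps the lowest number. 4-Nitrophenyl and 3-hydroxyphenyl cannot be told apart (no change at the digits printed from compound 2 to compound 4 (within the scatter)), while 4-nitrophenyl still stands well clear of 2-aminophenyl (a 15-fold lower number from compound 1 to compound 4 (1.18 log units; beyond the scatter)), which now has the highest number against three other aryl groups. Nothing at hand accounts for these steps.

Open, from the compounds shown here alone, is whether the nitrile or the nitro group itself matters, or where it sits on the phenyl ring. Unsubstituted phenyl, 3-nitrophenyl and 4-cyanophenyl would separate these.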